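The source may hold more compounds than are shown below. What is called first, only, known or untested is meant among the compounds shown, and "the series" means these compounds.

Of the compounds shown here, three have so far been measured in an assay on T-REx-293 cells for inhibition of potassium channel subfamily T member 1 (Homo sapiens), read by patch clamp; on this read-out higher numbers stand for weaker inhibition and lower numbers for stronger inhibition. Compound 1 `CCc1cc(C(=O)N[C@@H](C)c2nc(-c3cccc(C)c3)no2)n(C)n1` gives 335 nM. Compound 2 `Cc1cccc(-c2nnc([C@H](C)NC(=O)c3cc(C4CC4)nn3C)o2)c1` stops at > 30000 nM, which is a limit of the assay and not a number. Compound 3 `C[C@H](NC(=O)c1cc(C(F)(F)F)nn1C)c1nc(-c2ccccn2)no1` likewise stops at > 30000 nM, and this too is a limit rather than a measured number. Compound 3 therefore stands where no number could be read, sharing the limit of > 30000 nM in this assay, at which 2 of the 3 values shown sit, with compound 2, while compound 1 alone returns a value.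

Compound 4 `COc1cc(-c2noc([C@H](C)NC(=O)c3cc(C(F)(F)F)nn3C)n2)ccn1` has not yet been measured. It differs from compound 3 in one place: 2-methoxypyridin-4-yl in place of pyridin-2-yl on an aromatic carbon. Within the data shown here, no step between two measured compounds matches this change, so its size cannot be read from the data. Compound 1 alone, with 335 nM, shows that the shared core can give a numbered result in this assay. The step of an at least 3.0-fold lower number from compound 3 to compound 4 (0.47 log units; beyond the scatter) is expected to run toward stronger inhibition, though possibly not beyond the scatter. Compound 4 is estimated at 10000 nM, within 1000 nM to 30000 nM, with a fair chance that this assay again reports only a limit.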

Compound 4, half-maximal inhibitory concentration: 27 nM
Compound 4: middle estimate off by 370-fold (2.57 log units), on the high side; measured number outside the range, below it.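

In this assay, replacing pyridin-2-yl with 2-methoxypyridin-4-yl on the aromatic carbon between two ring nitrogen atoms gives an at least 1100-fold lower number from compound 3 to compound 4 (3.04 log units; beyond the scatter). With everything else in the molecule unchanged, this one group takes the read-out from no number to a measured one, so this position can strongly affect inhibition. The value of compound 3 is a limit and not a number, so the step has no upper end, and compound 3 does not stand alone at that limit: the limit of > 30000 nM in this assay, at which 2 of the 4 values shown sit.

The change moves the point of attachment on the pyridine and adds a methoxy group in a single step, and the compounds shown cannot separate these two parts. As far as these compounds go, it also remains open how a plain pyridin-4-yl, or an ethoxy group in place of the methoxy, would fare.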